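This account rests on a few compounds, and the source may have more. Where it says the series, first, only, none or still open, it means among the compounds named here.

Working notes on the series. In a physicochemical assay for lipophilicity, read by HPLC, in phosphate buffer, measured as octanol-water partition, with a stated time of 1 h, at pH 7.4 (on this read-out higher numbers stand for higher lipophilicity and lower numbers for lower lipophilicity), compound 1 `C[C@@]1(c2cc(NC(=O)c3ncc(C#N)cc3Cl)ccc2F)C=C(CF)OC(N)=N1` gives 2.5 and compound 2 `C[C@@]1(c2cc(NC(=O)c3ccc(C#N)cn3)ccc2F)C=C(CF)OC(N)=N1` gives 2.3, so the two stand within the scatter of each other. The next structure is compound 3 `C[C@@]1(c2cc(NC(=O)c3coc(CF)n3)ccc2F)C=C(CF)OC(N)=N1`, which is reached from compound 2 by 2-(fluoromethyl)-1,3-oxazol-4-yl in place of 5-cyanopyridin-2-yl on a carbonyl carbon. Going by the values given here, only one measured step is available, a number 0.20 log units lower from compound 1 to compound 2 (within the scatter), with hydrogen in place of chloro on an aromatic carbon. Among the compounds with values here, it bears only loosely on this change, since no measured step exchanges a whole group on the carbonyl carbon. The expectation therefore rests mainly on the structural change and stays uncertain. The expected step is modest and downward, a number 0.40 log units lower from compound 2 to compound 3 (beyond the scatter). The estimate for compound 3 is 1.9, with an expected range of 1.4 to 2.4.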

Compound 3, distribution coefficient: 2.2
Beside the measured number, compound 3's estimate is 0.30 log units below it; the range from low to high includes it.
By their numbers in this assay, from the lowest: compounds 3, 2 and 1 (each within the scatter of the next).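

In this assay, going by these compounds alone, the first whole-group exchange on the carbonyl carbon gives a number 0.10 log units lower from compound 2 to compound 3 (within the scatter), and the exchange of 3-chloro-5-cyanopyridin-2-yl for the same 2-(fluoromethyl)-1,3-oxazol-4-yl gives a number 0.30 log units lower from compound 1 to compound 3 (within the scatter). At this position, then, a five-membered aromatic ring with 2 hetero atoms takes the place of a six-membered one with 1 hetero atom, and the read-out stays within the scatter on both steps, so the earlier chloro-to-hydrogen result now extends to a change of the whole group. Nothing available gives a measured reason for this result.

The compounds shown leave open whether a group of another kind on the carbonyl carbon, such as a saturated amine or a carboxylic acid, would also stay within the scatter. They also leave open how much the fluoromethyl group itself contributes, as no 1,3-oxazol-4-yl group with a plain methyl or a hydrogen in its place appears among them.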